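Half-life notes on the isopropyl-to-ethyl step

This account rests on a few compounds, and the source may have more. Where it says the series, first, only, none or still open, it means among the compounds named here.

Measured in an in vivo ADME assay on the whole organism for metabolic stability, with Mus musculus as the target, read by LC-MS, at a dose of 160 mg/kg by the oral route; on this read-out higher numbers stand for a longer-lived compound and lower numbers for a shorter-lived compound:
compound 1 `CC(C)/N=C(\NC1=NC(=O)CN1c1ccc(Cl)c(Cl)c1)Nc1ccc(Cl)c(Cl)c1` — 0.454 h
compound 2 `CC(C)(C)N/C(=N/C1=NC(=O)CN1c1ccc(Cl)c(Cl)c1)Nc1ccc(Cl)c(Cl)c1` — > 1 h

Among the compounds with values here, compound 1 holds the only plain number in this assay among the measured pair. Compound 2 reports a limit rather than a number, namely (the limit of > 1 h in this assay, at which 1 of the 2 values shown sits). Within the data shown here, since the value of compound 2 is a limit, no step between compound 1 and compound 2 can be sized, and no pair of measured compounds differing in one place is available; compound 1 therefore stands alone as a reference point for this assay.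

Compound 3 `CC/N=C(\NC1=NC(=O)CN1c1ccc(Cl)c(Cl)c1)Nc1ccc(Cl)c(Cl)c1` differs from compound 1 in one place: hydrogen in place of methyl on a saturated chain carbon bound to a double-bonded nitrogen and a saturated chain carbon. The same difference, cut one bond further out, reads isopropyl to ethyl.

Among the measured compounds shown here, with no measured single-place step to lean on, the step from compound 1 to compound 3 in this assay is expected to be small, a 1.1-fold lower number from compound 1 to compound 3 (0.05 log units; within the scatter), and to lie within the usual scatter of repeated measurements. Compound 3 is accordingly estimated at 0.4 h in this assay, with a range from 0.2 h to 0.9 h.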

Compound 3, half-life: > 1 h
Compound 3 ended at the assay's limit; the forecaster's own chance of this, stated with the estimate: 10%; at least 2.5-fold (0.39 log units) between middle value and limit.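

Isopropyl to ethyl is not a silent change at this position. In this assay, within the data shown here, hydrogen in place of methyl on a saturated chain carbon bound to a double-bonded nitrogen and a saturated chain carbon gives an at least 2.2-fold higher number from compound 1 to compound 3 (0.34 log units; beyond the scatter), the first step that can be sized, since the earlier pair offered no single-place comparison. Compound 3 reports a limit and not a number, so this step fixes only a minimum size, and the read-out now gives limits for most of the compounds: the limit of > 1 h in this assay, at which 2 of the 3 values shown sit.

Going by these compounds, how large the step really is remains open, as does whether the half-life keeps following the substituent at this position once it is read as a plain number. Also open, on these data alone, is whether a methyl group, a longer chain such as n-propyl, or a cyclopropyl group in place of the isopropyl of compound 1 would give a half-life like that of compound 1 or would likewise reach the limit.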